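Replacing the propyl chain with a cyclopropyl group

The compounds below may be only part of what the source reports. "The series", "measured", "known", "first", "only" and "open" are said of these compounds alone.

Compound 1 `NC(C(=O)O)c1cnn(O)c1Br` gives > 1000000 nM in a functional assay on CHO cells for agonist activity at metabotropic glutamate receptor 1 (Rattus norvegicus), read by calcium flux (a higher number here means that more compound is needed for the effect, a lower number that less compound is needed), a limit of the assay.
Compound 2 `CCCc1c(C(N)C(=O)O)cnn1O` gives > 1000000 nM in this assay, a limit.
Compound 3 `CCCCc1c(C(N)C(=O)O)cnn1O` gives > 1000000 nM in this assay, a limit.

Compound 3 thus stands at the limit, where all three values sit (the limit of > 1000000 nM in this assay, at which 3 of the 3 values shown sit). Compound 4 `NC(C(=O)O)c1cnn(O)c1CC1CC1` differs from it in one place: cyclopropyl in place of propyl on a saturated chain carbon bound to an aromatic carbon. For the measured compounds named here, the steps that bear on this change, a step that the two limits leave unreadable from compound 1 to compound 3 and a step that the two limits leave unreadable from compound 2 to compound 3, are unreadable from the two limits, as is a step that the two limits leave unreadable from compound 1 to compound 2; no measured step shows any size. Nothing in these numbers points to a change beyond the scatter, so the expected step is a number no higher from compound 3 to compound 4 (the limit leaves the size open), none beyond the scatter. Compound 4 is therefore estimated at 1000000 nM, with a range from 300000 nM to 3000000 nM, most likely again as a limit.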

Compound 4, half-maximal effective concentration: > 1000000 nM
Compound 4 was reported as a limit (the forecaster's own chance of this, stated with the estimate: 90%); the middle value sits exactly at the limit.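

For the compounds shown here, compound 4 stands at the same limit as compound 1, compound 2 and compound 3, so no step to it can be read. The compounds shown leave open whether any of these groups on the shared core gives a measurable effect in this assay and how far apart the four compounds truly lie.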